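A few compounds are considered here, and "the series" means these few. Any claim that something is new, unique, unknown or untested is made for them only; others in the source may bear on it.

Measured so far:
compound 1, `O=S(=O)(Nc1ccc(-c2nc3ccccc3o2)cc1)c1cccc(F)c1`: > 63000 nM
compound 2, `O=S(=O)(Nc1ccc2oc(-c3ccccc3)nc2c1)c1ccc(Cl)c(C(F)(F)F)c1`: > 63000 nM
compound 3, `O=S(=O)(Nc1ccc2oc(-c3ccccc3)nc2c1)c1ccc(O)cc1`: > 63000 nM

All three were tested in an assay on isolated protein for inhibition of malate dehydrogenase, mitochondrial (Sus scrofa), with stated times of 45 min and 30 min; a higher number here means a weaker inhibitor, a lower number a stronger inhibitor. There compound 1 gives > 63000 nM, which is a limit of the assay rather than a number. Compound 2 gives > 63000 nM, also a limit. Compound 3 gives > 63000 nM, again a limit. So compound 1 stands nowhere apart from the others: every value shown sits at the limit of > 63000 nM in this assay, at which 3 of the 3 values shown sit, and no pair of them can be put in order.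

Compound 4, `CCc1ccc(S(=O)(=O)Nc2ccc(-c3nc4ccccc4o3)cc2)cc1`, has not yet been measured. It differs from compound 1 in one place: 4-ethylphenyl in place of 3-fluorophenyl on a sulfonyl sulfur. Among the measured compounds shown here, no step between measured compounds is available to gauge a change of this kind. Since compound 1 sits at the limit of > 63000 nM in this assay, at which 3 of the 3 values shown sit, the step of a number no higher from compound 1 to compound 4 (the limit leaves the size open) is expected to stay within the usual scatter, with no clear direction. Compound 4 is expected to give about 63000 nM in this assay, somewhere between 20000 nM and 200000 nM, and most likely again only a limit.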

Compound 4, half-maximal inhibitory concentration: > 63000 nM
Compound 4 was reported as a limit; the forecaster's own chance of this, stated with the estimate: 80%; the middle value lies on the limit itself.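

No step can be read from compound 1 to compound 4 in this assay, because both results are limits and not numbers: the limit of > 63000 nM in this assay, at which 4 of the 4 values shown sit.

The compounds shown leave open which change, if any, would give a value that this assay can report as a number.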